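Swapping fluoro for bromo on compound 2

A few compounds are considered here, and "the series" means these few. Any claim that something is new, unique, unknown or untested is made for them only; others in the source may bear on it.

- compound 1 `O=C(/C=C/c1cc(Cl)cc(Cl)c1Oc1c([N+](=O)[O-])cc(C(F)(F)F)cc1[N+](=O)[O-])c1ccc(F)cc1`: 29.4 ug/mL
- compound 2 `O=C(/C=C/c1cccc(Cl)c1Oc1c([N+](=O)[O-])cc(C(F)(F)F)cc1[N+](=O)[O-])c1ccc(F)cc1`: 23.8 ug/mL

Among the measured compounds shown here, in a functional assay on A549 cells (Homo sapiens) for antiproliferative activity, read by MTT assay, with a stated time of 48 h (on this read-out higher numbers stand for weaker inhibition and lower numbers for stronger inhibition), only two compounds have been measured so far. Compound 2, at 23.8 ug/mL, sits within the scatter of compound 1. For the measured compounds named here, the single measured step is a 1.2-fold lower number from compound 1 to compound 2 (0.09 log units; within the scatter); there, hydrogen takes the place of chloro on an aromatic carbon.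

Compound 3 `O=C(/C=C/c1cccc(Cl)c1Oc1c([N+](=O)[O-])cc(C(F)(F)F)cc1[N+](=O)[O-])c1ccc(Br)cc1` differs from compound 2 in one place: bromo in place of fluoro on an aromatic carbon. That is bromo in place of fluoro on an aromatic carbon. Going by the values given here, no measured step covers this swap. Among the compounds with values here, the one available step lies at a different place in the molecule, so it offers only a loose guide, and it stayed within the scatter. A small change is therefore expected, with no shift beyond the scatter in either direction. The expected step is a 1.1-fold lower number from compound 2 to compound 3 (0.05 log units; within the scatter). For compound 3 the estimated value is 21 ug/mL, with an expected range from 10 ug/mL to 42 ug/mL.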

Compound 3, half-maximal inhibitory concentration: 10.9 ug/mL
Compound 3: middle estimate off by 1.9-fold (0.28 log units), on the high side, and the stated range covers the measured number.
By their numbers in this assay, from the lowest: compound 3; then compounds 2 and 1 (each within the scatter of the next).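

Bromo in place of fluoro on this aromatic carbon gives a 2.2-fold lower number from compound 2 to compound 3 (0.34 log units; beyond the scatter) in this assay, a modest step that is nonetheless the first here to lie beyond the scatter. The earlier step, hydrogen in place of chloro, sat elsewhere in the molecule and stayed within the scatter, so it gave no sign that the halogen on the 4-fluorophenyl ring could change the read-out. This position therefore responds to at least one swap of halogen, although a single pair cannot show a trend across the halogens.

On these data alone, it remains open whether chloro or iodo at this same place would fit between or beyond these two results, and whether a non-halogen group such as methoxy or an amine would be tolerated. No measurement at hand says why bromo gives the lower number.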